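Nitro for Methoxy on a Weakly Cytotoxic Imine Core

A few compounds are considered here, and "the series" means these few. Any claim that something is new, unique, unknown or untested is made for them only; others in the source may bear on it.

Among the compounds with values here, compound 2 `COc1cccc(/C=N/c2c(C)n(C)n(-c3ccccc3)c2=O)c1` is one of two compounds measured in a functional assay on DLD-1 cells (Homo sapiens) for cytotoxicity, read by MTT assay, with a stated time of 72 h; on this read-out lower numbers stand for stronger inhibition and higher numbers for weaker inhibition. In this assay compound 2 gives 832000000 nM. Within the data shown here, its only measured neighbour is compound 1 `CCOc1cccc(/C=N/c2c(C)n(C)n(-c3ccccc3)c2=O)c1`, which in this assay gives 724000000 nM. The step of a 1.1-fold higher number from compound 1 to compound 2 (0.06 log units; within the scatter) shows that swapping the ethoxy chain for a methoxy chain leaves the read-out essentially unchanged, and compound 2 therefore stands, among these two numbers, as the higher one but within the scatter of compound 1.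

Compound 3 `Cc1c(/N=C/c2cccc([N+](=O)[O-])c2)c(=O)n(-c2ccccc2)n1C` differs from compound 2 by nitro in place of methoxy on an aromatic carbon. Among the measured compounds shown here, no measured step covers a change of this kind; the only step available, from compound 1 to compound 2, alters the chain on the oxygen rather than the group on the ring. Both measured values sit at a very high level, so the prior for any close analogue on this core is a similarly high number. Compound 3 is therefore expected to give a number close to that of compound 2, the step of a 1.0-fold lower number from compound 2 to compound 3 (0.02 log units; within the scatter) being expected to stay within the scatter. The estimate for compound 3 is 800000000 nM, with a range from 250000000 nM to 2500000000 nM.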

Compound 3, half-maximal inhibitory concentration: 490000000 nM
For compound 3 the middle estimate is 1.6-fold (0.21 log units) above the measured one; the range from low to high includes it.
By their numbers in this assay, from the lowest: compounds 3, 1 and 2 (each within the scatter of the next).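

In this assay, putting nitro on this aromatic carbon, meta to a large group, gives a 1.7-fold lower number from compound 2 to compound 3 (0.23 log units; within the scatter) and a 1.5-fold lower number from compound 1 to compound 3 (0.17 log units; within the scatter), and neither step leaves the scatter. Compound 1 and compound 2 had varied only the chain on the oxygen, with the oxygen itself kept on the ring; compound 3 shows that removing that oxygen-linked chain altogether and placing nitro on the same carbon also gives a number that cannot be told apart from theirs. Nothing available accounts for this outcome or assigns any measured property to either group at this position.

All three compounds therefore sit within the scatter of one another at a very high level, and they leave open whether any group on this carbon can move the number beyond the scatter, such as an amine, a carboxylic acid, a chlorine atom or a longer chain. They also leave open whether nitro would give a similar read-out on another carbon of the same ring, or whether the result would hold with the rest of the shared core altered.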